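The compounds below may be only part of what the source reports. "The series", "measured", "known", "first", "only" and "open" are said of these compounds alone.

Measured so far in an assay on isolated protein for inhibition of Indoleamine 2,3-dioxygenase 1 (Homo sapiens), read by spectrophotometry; a higher number here means a weaker inhibitor, a lower number a stronger inhibitor:
compound 1 `O=C(Cc1cccnc1)c1cc2ccccc2[nH]1` gives 65000 nM
compound 2 `O=C(Cc1cccnc1)c1[nH]c2ccccc2c1Br` gives "not active" (no number reported)

Going by the values given here, compound 1 holds the only number reported in this assay; compound 2 returned no value at all. Compound 3 `CC(C(=O)c1cc2ccccc2[nH]1)c1cccnc1` differs from compound 1 by methyl in place of hydrogen on a saturated chain carbon bound to an aromatic carbon and a carbonyl carbon. Among the compounds with values here, no pair of measured compounds shows what such a change does here, so in this assay no shift beyond the usual scatter is expected in either direction. Compound 3 is expected near 65000 nM, within 20000 nM to 200000 nM. The expected step of no change at the digits printed from compound 1 to compound 3 (within the scatter) is accordingly essentially flat, with a real chance that only a limit is reported.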

Compound 3, half-maximal inhibitory concentration: 141000 nM
For compound 3 the middle estimate is 2.2-fold (0.34 log units) below the measured one, within the range that was stated.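

In this assay methyl in place of hydrogen on a saturated chain carbon bound to an aromatic carbon and a carbonyl carbon gives a 2.2-fold higher number from compound 1 to compound 3 (0.34 log units; beyond the scatter) and so moves the series toward weaker inhibition. Going by these compounds alone, this is the first reading at this position, and it shows that the position does not tolerate this change without a modest loss. No supporting measurement bears on the origin of this step. Going by these compounds, whether an ethyl group, a longer chain or an amine on the same carbon would follow the direction of methyl remains open. The effect of a hydroxyl group there is equally unsettled.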